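From Chloro to Bromo on a Chromone Ether

The compounds below may be only part of what the source reports. "The series", "measured", "known", "first", "only" and "open" are said of these compounds alone.

Of the compounds shown here, two sharing one core have been measured in an assay on microsomes for inhibition of Amine oxidase [flavin-containing] B (Homo sapiens), read by fluorescence and spectrophotometry, with a stated time of 20 min; a lower number here means a stronger inhibitor, a higher number a weaker inhibitor. Compound 1 `O=c1ccoc2ccc(OCCCc3ccccc3)cc12` gives 57 nM in this assay, while compound 2 `O=c1ccoc2ccc(OCc3cccc(Cl)c3)cc12` gives 3.6 nM, the lower of the two numbers; the gap between compound 1 and compound 2 lies beyond the usual scatter, so compound 2 stands as the stronger inhibitor of the pair. Compound 3 `O=c1ccoc2ccc(OCc3cccc(Br)c3)cc12` has not yet been measured. It differs from compound 2 in one place: bromo in place of chloro on an aromatic carbon. For the measured compounds named here, no measured pair here shows what this exchange does, so the expectation rests on the value of compound 2 alone. For compound 3 the step of a 1.0-fold lower number from compound 2 to compound 3 (0.01 log units; within the scatter) is expected to stay within the scatter, with no clear direction. Compound 3 is therefore estimated at 3.5 nM, within 1.2 nM to 10 nM.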

Compound 3, half-maximal inhibitory concentration: 2 nM
Beside the measured number, compound 3's estimate is 1.8-fold (0.24 log units) above it; the range from low to high includes it.
By their numbers in this assay, from the lowest: compounds 3 and 2 (each within the scatter of the next); then compound 1.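

The earlier compounds shown here gave no reading of what a halogen exchange does on this aromatic carbon, which sits meta to a large group. In this assay, bromo in place of chloro gives a 1.8-fold lower number from compound 2 to compound 3 (0.26 log units; within the scatter) and so the two halogens cannot be told apart at this position, which shows that this exchange leaves the number inside the scatter. The data shown offer no explanation for this outcome.

The compounds shown leave open what other groups would give on this same carbon, for instance fluoro, methoxy or trifluoromethyl. Also open, on these data alone, is whether a larger change there, such as an amine or a carboxylic acid in place of the halogen, would leave the number where chloro and bromo put it.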